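The source may hold more compounds than are shown below. What is called first, only, known or untested is meant among the compounds shown, and "the series" means these compounds.

Compound 1 `CCS(=O)(=O)Nc1cc(-c2ccc3ncnc(Nc4ccc(OC)cc4)c3c2)cnc1OC` was tested in a functional assay on SK-HEP1 cells (Homo sapiens) for cytotoxicity, read by sulforhodamine B assay, with a stated time of 72 h (a lower number here means a stronger inhibitor, a higher number a weaker inhibitor), and gives 1610 nM. Among the three measured compounds, compound 1 shows the lowest number, though compound 3 `COC(=O)c1cccc(Nc2ncnc3ccc(-c4cnc(OC)c(NS(=O)(=O)c5ccc(F)cc5F)c4)cc23)c1` sits within the usual scatter of it at 2800 nM, whereas compound 2 `CCCCS(=O)(=O)Nc1cc(-c2ccc3ncnc(Nc4ccc(F)c(Cl)c4)c3c2)cnc1OC`, with 53800 nM, lies clearly beyond it. Compound 4 `CCS(=O)(=O)Nc1cc(-c2ccc3ncnc(Nc4ccc(F)nc4)c3c2)cnc1OC` has not yet been measured; it differs from compound 1 only in one place: 6-fluoropyridin-3-yl in place of 4-methoxyphenyl on a nitrogen on an aromatic ring. Among the compounds with values here, no measured pair shows this exchange, so its effect is unknown here. A modest step is expected, if any, somewhat toward a weaker inhibitor but possibly within the scatter, giving an estimated 1.6-fold higher number from compound 1 to compound 4 (0.19 log units; within the scatter). Compound 4 is therefore expected to show about 2500 nM, with a plausible range from 800 nM to 8000 nM.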

Compound 4, half-maximal inhibitory concentration: 5240 nM
Compound 4: the middle estimate sits 2.1-fold (0.32 log units) below what was measured, and the stated range covers the measured number.
By their numbers in this assay, from the lowest: compounds 1, 3 and 4 (each within the scatter of the next, the first and the last beyond it); then compound 2.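

On this nitrogen on an aromatic ring, the exchange of 4-methoxyphenyl for 6-fluoropyridin-3-yl in this assay gives a 3.3-fold higher number from compound 1 to compound 4 (0.51 log units; beyond the scatter) and so moves toward a weaker inhibitor. Within the data shown here, this is the first single-place comparison, and it shows that the number responds to the group at this position even when the rest of the structure stays the same. Nothing available accounts for this step.

Going by these compounds, the exchange alters the ring and its substituent together, so the shares of the ring nitrogen and the fluorine remain open. An unsubstituted pyridin-3-yl or a 4-fluorophenyl group would separate the two.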